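The compounds below may be only part of what the source reports. "The series", "measured", "known", "first", "only" and "open" are said of these compounds alone.

In a physicochemical assay for lipophilicity (a higher number here means a more lipophilic compound, a lower number a more polar compound), compound 1 (`CS(=O)(=O)Cc1cc(C2=CCOCC2)nc(-c2cccc(O)c2)n1`) gives 3.3 and compound 2 (`CNCC(=O)Nc1ccc(-c2nc(CS(C)(=O)=O)cc([C@@]34CCOC[C@@H]3C4)n2)cc1`) gives 3.1, so the two values lie within the scatter of each other. Compound 3 (`Oc1cccc(-c2nccc(C3=CCOCC3)n2)c1`) differs from compound 1 by hydrogen in place of (methylsulfonyl)methyl on an aromatic carbon, with hydrogen in place of (methylsulfonyl)methyl on an aromatic carbon. For the measured compounds named here, no measured pair isolates this change, so the expectation rests on the structural change alone. A rise somewhat beyond the scatter is expected in this assay, with the estimated change being a number 0.50 log units higher from compound 1 to compound 3 (beyond the scatter). Compound 3 is estimated at 3.8, with an expected range of 3.4 to 4.3.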

Compound 3, partition coefficient: 3.6
For compound 3 the middle estimate is 0.20 log units above the measured one; measured number inside the range.
By their numbers in this assay, from the lowest: compounds 2, 1 and 3 (each within the scatter of the next, the first and the last beyond it).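

For the compounds shown here, at this aromatic carbon, a number 0.30 log units higher from compound 1 to compound 3 (within the scatter) is the step in this assay for hydrogen in place of (methylsulfonyl)methyl, the first direct reading at this position. Taking away all 5 heavy atoms of that group therefore leaves compound 3 within the scatter of compound 1 on this scale. Nothing at hand gives a reason for this step. Still open, going by these compounds, is whether an amine, a carboxylic acid or a longer chain at this carbon would also stay within the scatter of compound 1. Also open, on these data alone, is whether the same step would hold on the core of compound 2.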